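This account rests on a few compounds, and the source may have more. Where it says the series, first, only, none or still open, it means among the compounds named here.

Three close relatives sharing one core have been examined in a functional assay on L6 cells (Rattus norvegicus) for inhibition (on this read-out lower numbers stand for stronger inhibition and higher numbers for weaker inhibition), but only one of them has yielded a number. In this assay compound 1 (`Cc1ccccc1CNC(=O)c1nn(-c2ccc(F)cc2)c(OC[C@@H](O)C[C@@H](O)CC(=O)O)c1C(C)C`) gives 2850 nM. Compound 2 (`COc1ccccc1CNC(=O)c1nn(-c2ccc(F)cc2)c(OC[C@@H](O)C[C@@H](O)CC(=O)O)c1C(C)C`) stands at "not determined" (no result reported), and compound 3 (`CC(C)c1c(C(=O)NCc2ccc(Cl)cc2)nn(-c2ccc(F)cc2)c1OC[C@@H](O)C[C@@H](O)CC(=O)O`) likewise stands at "not determined" (no result reported). Compound 3 therefore has no place on the numerical scale, and it cannot be ranked against compound 1.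

The next compound is compound 4 (`CC(C)c1c(C(=O)NCc2ccccc2Cl)nn(-c2ccc(F)cc2)c1OC[C@@H](O)C[C@@H](O)CC(=O)O`), which carries 2-chlorophenyl in place of 4-chlorophenyl on a saturated chain carbon bound to an amide-type nitrogen. The two have the same atoms, joined differently. With no number for compound 3, the size of this step cannot be measured, and the data give no reason to expect a shift in either direction. Going by the values given here, the only anchor is compound 1 at 2850 nM, and no step beyond the usual scatter from that level is expected in this assay. The expected value for compound 4 is 2500 nM, with an estimated range of 800 nM to 8000 nM.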

Compound 4, half-maximal inhibitory concentration: 8450 nM
Beside the measured number, compound 4's estimate is 3.4-fold (0.53 log units) below it; the whole stated range lies below it.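

With compound 4, this position gains its first readable step: in this assay, chloro in place of methyl on an aromatic carbon gives a 3.0-fold higher number from compound 1 to compound 4 (0.47 log units; beyond the scatter), which means weaker inhibition. The read-out therefore responds beyond the usual scatter to this single exchange on the group attached to the amide-type nitrogen. Steps involving compound 2 or compound 3 cannot be read, so the effect of 2-chlorophenyl in place of 4-chlorophenyl remains unknown. Nothing given here accounts for the step from methyl to chloro.

The compounds shown leave open whether a fluoro, bromo or nitrile group on the same aromatic carbon would give a value closer to that of compound 1 or compound 4. They also leave open whether a hydroxyl group there would give stronger inhibition than methyl.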